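The compounds below may be only part of what the source reports. "The series", "measured", "known", "first", "only" and "open" are said of these compounds alone.

Measured compounds: compound 1 `CCCCSc1n[nH]c(-n2[se]c3ccccc3c2=O)n1` gives 30400 nM in an ADME assay on L929 cells (Mus musculus) for antiproliferative activity, read by CCK-8 assay, with a stated time of 48 h; a higher number here means a weaker inhibitor, a lower number a stronger inhibitor; compound 2 `CCSc1n[nH]c(-n2[se]c3ccccc3c2=O)n1` gives 35200 nM in this assay. Compound 3 `Cc1cccc(CSc2n[nH]c(-n3[se]c4ccccc4c3=O)n2)c1` reaches only a limit of this assay, > 50000 nM (the limit of > 50000 nM in this assay, at which 1 of the 3 values shown sits).

Compound 3 therefore stands at the limit rather than at a number. The steps toward it, an at least 1.6-fold higher number from compound 1 to compound 3 (0.21 log units; that floor lies within the scatter) and an at least 1.4-fold higher number from compound 2 to compound 3 (0.15 log units; that floor lies within the scatter), have floors that lie within the scatter and fix no direction. Compound 4 `O=c1c2ccccc2[se]n1-c1nc(SCc2ccc(F)cc2)n[nH]1` differs from compound 3 by 4-fluorophenyl in place of 3-methylphenyl on a saturated chain carbon bound to a sulfur. Within the data shown here, no measured step exchanges one aryl group for another, so no step beyond the scatter is expected here. Compound 4 is estimated at 60000 nM, with a range from 30000 nM to 120000 nM, most likely reported again as a limit. The expected step is a step that the limit leaves unreadable from compound 3 to compound 4.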

Compound 4, half-maximal inhibitory concentration: > 50000 nM
Compound 4: a limit, no number; the forecaster's own chance of this, stated with the estimate: 70%; the middle value lies beyond the limit too.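

Compound 4 reaches only a limit in this assay as compound 3 does, so both benzyl groups shown at this position end at a limit: the limit of > 50000 nM in this assay, at which 2 of the 4 values shown sit. Neither an at least 1.4-fold higher number from compound 2 to compound 4 (0.15 log units; that floor lies within the scatter) nor an at least 1.6-fold higher number from compound 1 to compound 4 (0.21 log units; that floor lies within the scatter) fixes a direction against the short chains. The step between compound 3 and compound 4 cannot be read, so this exchange of 3-methylphenyl for 4-fluorophenyl has no measured size. As far as these compounds go, whether an amine on the 4-fluorobenzyl group, or a chain longer than that of compound 1, would give a number in this assay stays open.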